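The compounds below may be only part of what the source reports. "The series", "measured", "known", "first", "only" and "open" are said of these compounds alone.

Compound 1 `Cn1c(=O)c(=O)n(C2CCCC2)c2nc(N/N=C/c3ccc(O)cc3)ncc21` is one of three hydrazone analogues on a shared core tested in a functional assay on HCT-116 cells (Homo sapiens) for antiproliferative activity, read by MTT assay (a higher number here means a weaker inhibitor, a lower number a stronger inhibitor), where compound 1 gives 72500 nM. Compound 2 `Cn1c(=O)c(=O)n(C2CCCC2)c2nc(N/N=C/c3ccco3)ncc21` gives 78700 nM and compound 3 `Cn1c(=O)c(=O)n(C2CCCC2)c2nc(N/N=C/c3cccc(O)c3)ncc21` gives 37200 nM, so compound 1 stands second highest of the three numbers; the step of a 1.1-fold higher number from compound 1 to compound 2 (0.04 log units; within the scatter) and the step of a 1.9-fold lower number from compound 1 to compound 3 (0.29 log units; within the scatter) both stay within the scatter, while the step of a 2.1-fold lower number from compound 2 to compound 3 (0.33 log units; beyond the scatter) is modest. Compound 4 `Cn1c(=O)c(=O)n(C2CCCC2)c2nc(N/N=C/c3cccc([N+](=O)[O-])c3)ncc21` differs from compound 1 by 3-nitrophenyl in place of 4-hydroxyphenyl on a carbon with a double bond to nitrogen. Within the data shown here, no measured step introduces a nitro group; the step from compound 1 to compound 3 is the closest guide, having moved the substituent on the ring. Compound 4 is therefore expected to show a 1.5-fold lower number from compound 1 to compound 4 (0.16 log units; within the scatter) in this assay, with an estimate of 50000 nM and a range of 18000 nM to 140000 nM.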

Compound 4, half-maximal inhibitory concentration: 15200 nM
Beside the measured number, compound 4's estimate is 3.3-fold (0.52 log units) above it, outside the stated range (below it).
By their numbers in this assay, from the lowest: compound 4; then compounds 3, 1 and 2 (each within the scatter of the next, the first and the last beyond it).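

In this assay the 3-nitrophenyl group is the first on this carbon with a double bond to nitrogen to stand clear of all the other groups shown (a 4.8-fold lower number from compound 1 to compound 4 (0.68 log units; beyond the scatter); a 5.2-fold lower number from compound 2 to compound 4 (0.71 log units; beyond the scatter)). Nitro in place of hydroxy on an aromatic carbon also lowers the number (a 2.4-fold lower number from compound 3 to compound 4 (0.39 log units; beyond the scatter)), so the choice of substituent matters here, not only the swap away from 4-hydroxyphenyl. Nothing available explains why this change lowers the number.

On these data alone, whether 4-nitrophenyl would give a similar number remains open. So does whether an amine or a carboxylic acid in place of the nitro group would keep it.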